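Amine tail variation on the shared core

The source may hold more compounds than are shown below. What is called first, only, known or untested is meant among the compounds shown, and "the series" means these compounds.

Measured so far:
- compound 1 `COc1ccc2c(c1)C(C(C)c1ccccn1)=C(CCN(C)C)C2`: in an assay on CHO-K1 cells for binding affinity to muscarinic acetylcholine receptor M5 (Homo sapiens) (on this read-out higher numbers stand for weaker inhibition and lower numbers for stronger inhibition), compound 1 gives 8910 nM
- compound 2 `CC(C1=C(CCN2CCCCC2)Cc2ccccc21)c1ccccn1`: in this assay compound 2 gives 2340 nM

Compound 2 holds the lower of the two numbers; compound 1 sits beyond the scatter above it. Compounds 1 and 2 differ in more than one place, so no single-point step can be read between them, and their two values show only this gap. Compound 3 `CC(C1=C(CCCN(C)C)Cc2ccccc21)c1ccccn1` is not yet measured. It differs from compound 2 in one place: (dimethylamino)methyl in place of piperidin-1-yl on a saturated chain carbon, two bonds along the chain from a double-bonded ring carbon. The ring leaves and an open chain enters. For the measured compounds named here, no step between measured compounds speaks to this change; the expectation rests on compound 2 alone, anchored at 2340 nM in this assay. A step within the scatter, with no settled direction, is expected, a 1.3-fold higher number from compound 2 to compound 3 (0.11 log units; within the scatter). For compound 3 the estimate in this assay is 3000 nM, with a range from 1000 nM to 10000 nM.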

Compound 3, inhibition constant: 3240 nM
Compound 3: the middle estimate sits 1.1-fold (0.03 log units) below what was measured, within the range that was stated.
By their numbers in this assay, from the lowest: compounds 2 and 3 (each within the scatter of the next); then compound 1.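

In this assay, the change reads as a step of a 1.4-fold higher number from compound 2 to compound 3 (0.14 log units; within the scatter), so on a saturated chain carbon, two bonds along the chain from a double-bonded ring carbon, the open (dimethylamino)methyl and the ring-bearing piperidin-1-yl cannot be told apart. For the compounds shown here, compound 1 and compound 2 differ in more than one place and showed only a gap, so this is the first step that can be read for a single change. Nothing at hand bears on why the two tails read alike.

Still open, from the compounds shown here alone, is whether a morpholine or a primary amine at this place, or a longer chain, would stay within the scatter of compound 2. The methoxy group of compound 1 also remains unresolved, as its share in that gap cannot be read from these compounds.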